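Cycloheptyl for Cyclopropyl: Expected Effect in the Rat

This account rests on a few compounds, and the source may have more. Where it says the series, first, only, none or still open, it means among the compounds named here.

Compound 1, `c1ccc(C(/N=C2\CCCCCN2)C2CC2)cc1`: 51% in a functional assay on the whole organism (plasma, strain Sprague-Dawley) with Rattus norvegicus as the target, with a stated time of 2 h, at a dose of 100 mg/kg by the oral route; a lower number here means a weaker effect, a higher number a stronger effect of the compound at the dose given
Compound 2, `COc1ccc(C(/N=C2\CCCCCN2)C2CC2)cc1`: 40%
Compound 3, `Cc1ccc(C(/N=C2\CCCCCN2)C2CC2)c(C)c1`: 56%

Among the three measured compounds, compound 1 stands second highest: compound 3 is nearest, within the scatter of it, while compound 2 lies farther off, lower by a number 11 percentage points lower from compound 1 to compound 2 (beyond the scatter). Compound 4, `c1ccc(C(/N=C2\CCCCCN2)C2CCCCCC2)cc1`, differs from compound 1 by cycloheptyl in place of cyclopropyl on a saturated chain carbon bound to an aromatic carbon and a double-bonded nitrogen. For the measured compounds named here, the only measured step concerns a methoxy group on the aromatic ring, not the saturated carbon where the ring size changes, so no measured step bears directly on this change. Nothing in these numbers therefore points to a step beyond the scatter in this assay, and the expected step is a number 1 percentage points lower from compound 1 to compound 4 (within the scatter). Compound 4 is estimated at 50%, with a range from 25% to 75%.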

Compound 4, a percentage reported as inhibition, in the whole organism at one dose (the size of the read-out at that dose, not a potency): 6%
For compound 4 the middle estimate is 44 percentage points above the measured one; measured number below the stated range.
By their numbers in this assay, from the lowest: compound 4; then compound 2; then compounds 1 and 3 (each within the scatter of the next).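

The earlier compounds shown here varied only the aromatic ring, whereas this result shows that the saturated carbon bound to the aromatic carbon and the double-bonded nitrogen also matters. In this assay, cycloheptyl in place of cyclopropyl gives a number 45 percentage points lower from compound 1 to compound 4 (beyond the scatter), so the effect at this dose depends strongly on the group at that carbon. The information at hand gives no reason for this step.

As far as these compounds go, whether the effect falls gradually with ring size or only beyond a certain size remains open. Cyclobutyl, cyclopentyl or cyclohexyl at this carbon could separate these possibilities, and an isopropyl group would test an open chain there.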